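The source may hold more compounds than are shown below. What is called first, only, known or untested is meant among the compounds shown, and "the series" means these compounds.

Measured so far:
- compound 1, `CCC1(Cc2ccccc2)OS(=O)(=O)C=C1OCc1ccc(F)cc1`: > 50000 nM
- compound 2, `CCC1(Cc2ccccc2)OS(=O)(=O)C=C1OCc1ccc(Cl)c(Cl)c1`: 36700 nM

In an ADME assay on HEL cells (Homo sapiens) for cytotoxicity, with a stated time of 3 days (a lower number here means that less compound is tolerated, a higher number that more compound is tolerated), compound 1 gives only a limit, > 50000 nM, so no number is known for it. In this assay, for the measured compounds named here, compound 2 gives 36700 nM, the only actual number among the two values shown. The other value, that of compound 1, is a limit, as noted by the limit of > 50000 nM in this assay, at which 1 of the 2 values shown sits. Going by the values given here, the one measured step, an at least 1.3-fold lower number from compound 1 to compound 2 (0.13 log units; that floor lies within the scatter), is a change of 3,4-dichlorophenyl in place of 4-fluorophenyl on a saturated chain carbon bound to an oxygen on an unsaturated carbon, and its size cannot be separated from the scatter.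

Compound 3, `CCC1(Cc2ccccc2)OS(=O)(=O)C=C1OCC=C(C)C`, has not been measured. It differs from compound 2 as follows: 2-methylprop-1-en-1-yl in place of 3,4-dichlorophenyl on a saturated chain carbon bound to an oxygen on an unsaturated carbon. Among the compounds with values here, the only step that bears on this change is an at least 1.3-fold lower number from compound 1 to compound 2 (0.13 log units; that floor lies within the scatter), which swapped one aromatic group for another at the same place and stayed within the scatter. Nothing in the data points to a step beyond the scatter in either direction for a change at this position. Compound 3 is therefore expected to give about 45000 nM in this assay, within a range from 20000 nM to 100000 nM. That estimate means a step of a 1.2-fold higher number from compound 2 to compound 3 (0.09 log units; within the scatter), expected to stay within the scatter.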

Compound 3, half-maximal cytotoxic concentration: 112000 nM
For compound 3 the middle estimate is 2.5-fold (0.40 log units) below the measured one; the measured number lies above the stated range.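

At this place, on a saturated chain carbon bound to an oxygen on an unsaturated carbon, replacing 3,4-dichlorophenyl with 2-methylprop-1-en-1-yl gives in this assay a 3.1-fold higher number from compound 2 to compound 3 (0.48 log units; beyond the scatter) and so shows that the group here can move the read-out by more than the scatter, which the earlier swap of one aromatic group for another could not show. This is also the first change shown that leaves an aromatic ring for a group with no ring, and more compound is tolerated after it, although this one pair cannot separate the loss of the ring from the loss of the chlorine atoms or from the smaller group. Compound 1 carries only a limit, so its step to compound 3 cannot be read: the limit of > 50000 nM in this assay, at which 1 of the 3 values shown sits.

The compounds shown leave open whether the double bond of 2-methylprop-1-en-1-yl matters, since a fully saturated chain of the same kind or a longer chain would be needed to tell. They also leave open how an unsubstituted phenyl, an amine or a carboxylic acid at this place would behave.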